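From Compound 2 to Compound 4: A Nitrile Swap

A few compounds are considered here, and "the series" means these few. Any claim that something is new, unique, unknown or untested is made for them only; others in the source may bear on it.

Of the compounds shown here, three have been tested in an assay on HEK293 cells for inhibition of Voltage-dependent T-type calcium channel subunit alpha-1H (Homo sapiens), using a membrane potential dye; on this read-out lower numbers stand for stronger inhibition and higher numbers for weaker inhibition. Compound 1 `CC(C)N1CC2(CCN(C(=O)Nc3ccc(F)c(F)c3)CC2)C1c1ccc(Cl)cc1` gives 340 nM, compound 3 `O=C(Nc1ccc(F)c(F)c1)N1CCC2(CC1)C(=O)N(c1cccc(Cl)c1)C2c1ccccn1` gives 118 nM, and compound 2 `O=C(Nc1cc(F)cc(F)c1)N1CCC2(CC1)C(=O)N(c1ccc(F)c(Cl)c1)C2c1ccccn1` gives 42 nM, the lowest number of the three and beyond the scatter from each of the others. Compound 4 `N#Cc1cccc(N2C(=O)C3(CCN(C(=O)Nc4cc(F)cc(F)c4)CC3)C2c2ccccn2)c1` has not yet been measured; it differs from compound 2 by 3-cyanophenyl in place of 3-chloro-4-fluorophenyl on an amide-type nitrogen in a ring. Among the compounds with values here, no measured pair isolates this change, so the expectation rests on compound 2 alone. In this assay the step from compound 2 to compound 4 is expected to be a 2.1-fold higher number from compound 2 to compound 4 (0.33 log units; beyond the scatter), a small move toward weaker inhibition that may not exceed the scatter. Compound 4 is therefore estimated at 90 nM, within a range from 30 nM to 300 nM.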

Compound 4, half-maximal inhibitory concentration: 19300 nM
Compound 4: the middle estimate sits 210-fold (2.33 log units) below what was measured; the measured number lies above the stated range.
By their numbers in this assay, from the lowest: compound 2; then compound 3; then compound 1; then compound 4.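

In this assay, the group on the amide-type nitrogen of the four-membered ring proves decisive: 3-cyanophenyl in place of 3-chloro-4-fluorophenyl brings a 460-fold higher number from compound 2 to compound 4 (2.66 log units; beyond the scatter), a large move toward weaker inhibition. Both groups count 8 heavy atoms and one six-membered aromatic ring, so a match on those counts does not keep inhibition here. Within the data shown here, nothing measured so far explains this gap.

Still open, as far as these compounds go, is whether the loss follows from removing the chlorine, removing the fluorine or adding the nitrile. Also open, from the compounds shown here alone, is how a phenyl ring carrying a methoxy group or an amine would fare at this place.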